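A few compounds are considered here, and "the series" means these few. Any claim that something is new, unique, unknown or untested is made for them only; others in the source may bear on it.

Measured so far in a functional assay on PC-3 cells (Homo sapiens) for inhibition, read by MTT assay, with a stated time of 48 h, tested at 10 uM; a lower number here means less inhibition of growth, a higher number more inhibition of growth at the concentration tested:
- compound 1, `Cc1cc(=O)c2c(O)c(CN3CCCC3CO)c(O)c([C@H]3CCN(C)C[C@H]3O)c2o1` — compound 1 gives 15%
- compound 2, `CCOC(=O)N1CCN(Cc2c(O)c([C@H]3CCN(C)C[C@H]3O)c3oc(C)cc(=O)c3c2O)CC1` — compound 2 gives 1%

For the measured compounds named here, compound 2 stands lowest of the two numbers; the one measured step, a number 14 percentage points lower from compound 1 to compound 2 (beyond the scatter), separates it from compound 1 and is beyond the scatter.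

The next compound is compound 3, `Cc1cc(=O)c2c(O)c(CN3CCCC3C(=O)O)c(O)c([C@H]3CCN(C)C[C@H]3O)c2o1`. Its change from compound 2 is 2-carboxypyrrolidin-1-yl in place of 4-(ethoxycarbonyl)piperazin-1-yl on a saturated chain carbon bound to an aromatic carbon. This is close to a reversal of the measured step: the pyrrolidine with a one-carbon substituent returns on the saturated chain carbon bound to an aromatic carbon, though with a carboxy group where compound 1 carries hydroxymethyl. Going by the values given here, the only step that bears on it is a number 14 percentage points lower from compound 1 to compound 2 (beyond the scatter), a modest drop when the pyrrolidine was exchanged for the piperazine carbamate. Going back to a pyrrolidine is therefore expected to recover part of that drop, but the carboxy group is untested in this series, so the expected step in this assay is upward and small, a number 9 percentage points higher from compound 2 to compound 3 (within the scatter), at the edge of the scatter. Compound 3 is estimated at 10%, within 0% to 24%.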

Compound 3, percent growth inhibition at one concentration: 0%
Compound 3: middle estimate off by 10 percentage points, on the high side; measured number inside the range.
By their numbers in this assay, from the lowest: compounds 3 and 2 (each within the scatter of the next); then compound 1.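

Within this assay, the 2-carboxypyrrolidin-1-yl group does not keep the number of compound 1: carboxy in place of hydroxymethyl on a saturated ring carbon gives a number 15 percentage points lower from compound 1 to compound 3 (beyond the scatter), so the five-membered ring alone does not account for the value of that compound, and the substituent on the ring also counts. On the saturated chain carbon bound to an aromatic carbon, 2-carboxypyrrolidin-1-yl in place of 4-(ethoxycarbonyl)piperazin-1-yl gives a number 1 percentage points lower from compound 2 to compound 3 (within the scatter), so these two groups cannot be told apart here despite their different rings, and of the three groups shown at this place only 2-(hydroxymethyl)pyrrolidin-1-yl stands clear of the others, with compound 1 at 15%. No evidence on hand bears on the reason for these differences.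

As far as these compounds go, whether a methyl ester or a primary amide in place of the carboxy group, or a longer chain such as 2-hydroxyethyl in place of hydroxymethyl, would hold the number of compound 1 remains open. So does the effect of an unsubstituted pyrrolidine at this place, which would separate the ring from its substituent.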